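Bromine in Place of Furan on a Scaffold Without Cytotoxicity

This account rests on a few compounds, and the source may have more. Where it says the series, first, only, none or still open, it means among the compounds named here.

Compound 1 `CC(C)N(Cc1cccc(OCCCCCC(=O)O)c1)C(=O)c1ccc(-c2ccoc2)cc1`: in an ADME assay on HepG2 cells (Homo sapiens) for cytotoxicity, read by CellTiter-Glo and resazurin assay, with a stated time of 72 h (a lower number here means that less compound is needed, a higher number that more compound is needed for the effect), compound 1 gives > 26000 nM, a limit of the assay rather than a number.
Compound 2 `CC(C)N(Cc1cccc(OCCCCCC(=O)O)c1)C(=O)c1ccc(-c2cccc(OC(F)(F)F)c2)cc1`: in this assay compound 2 gives > 26000 nM, again a limit.
Compound 3 `CCOC(=O)CCCCCOc1cccc(CN(C(=O)c2ccc(-c3ccoc3)cc2)C(C)C)c1`: in this assay compound 3 gives > 26000 nM, also a limit.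

Compound 3 therefore stands where every measured compound stands, at the limit of > 26000 nM in this assay, at which 3 of the 3 values shown sit, and no number places it apart from compound 1 or compound 2. The two measured steps, a step that the two limits leave unreadable from compound 1 to compound 2 and a step that the two limits leave unreadable from compound 1 to compound 3, are both hidden by limits on either side, so neither gives a readable size.

Compound 4 `CCOC(=O)CCCCCOc1cccc(CN(C(=O)c2ccc(Br)cc2)C(C)C)c1` differs from compound 3 as follows: bromo in place of furan-3-yl on an aromatic carbon. Going by the values given here, no measured step speaks to this change, and the only evidence at hand is that three compounds of the shared core all sit at the limit. On that basis compound 4 is expected to remain at or beyond that limit in this assay, with a step that the limit leaves unreadable from compound 3 to compound 4 expected to stay within scatter. The estimate for compound 4 is 30000 nM, between 13000 nM and 80000 nM.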

Compound 4, half-maximal effective concentration: > 26000 nM
Compound 4: no number, only a limit (the forecaster's own chance of this, stated with the estimate: 80%); the middle value lies beyond the limit too.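

The step from compound 3 to compound 4 cannot be read, as both give only a limit of this assay, not a number. The compounds shown leave open whether any change to the shared core would bring a value within the measurable range.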